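This account rests on a few compounds, and the source may have more. Where it says the series, first, only, none or still open, it means among the compounds named here.

The study concerns two measured compounds and one that has not yet been tested, all compared in an assay on isolated protein for inhibition of Polyunsaturated fatty acid 5-lipoxygenase (Homo sapiens), read by HPLC, with a stated time of 15 min, in the presence of a further agent that is not named here; on this read-out higher numbers stand for weaker inhibition and lower numbers for stronger inhibition. Compound 1 `CCCCC(Sc1ccc(OCCCOc2ccc3ncccc3c2)cc1)C(=O)OCC` gives 800 nM in this assay. Compound 2 `CCCCC(Sc1ccc(OCCCOc2ccc(C)cc2)cc1)C(=O)O` gives 5200 nM in this assay, the highest of the two numbers recorded; its nearest neighbour is compound 1, whose lower number lies beyond the usual scatter, so compound 2 is the weaker inhibitor of the pair.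

Compound 3 `CCCCC(Sc1ccc(OCCCOc2cccc(C)c2)cc1)C(=O)O` is the next compound to be measured. It differs from compound 2 only in the arrangement of the same atoms: 3-methylphenyl in place of 4-methylphenyl on an oxygen on a saturated carbon. Among the measured compounds shown here, no measured pair in this set shows the effect of such a change, so there is no step to lean on. The change is expected to leave the number close to that of compound 2, with a 1.2-fold lower number from compound 2 to compound 3 (0.06 log units; within the scatter) lying within the scatter in either direction. Compound 3 is therefore estimated at 4500 nM, with a range from 2000 nM to 12000 nM.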

Compound 3, half-maximal inhibitory concentration: 4800 nM
Compound 3: the middle estimate sits 1.1-fold (0.03 log units) below what was measured, within the range that was stated.
By their numbers in this assay, from the lowest: compound 1; then compounds 3 and 2 (each within the scatter of the next).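

In this assay, placing 3-methylphenyl in place of 4-methylphenyl on an oxygen on a saturated carbon gives a 1.1-fold lower number from compound 2 to compound 3 (0.03 log units; within the scatter). Among the compounds shown here, this is the first step read at this position, and it shows that the assay does not distinguish these two arrangements of the same atoms in this pair. Nothing available explains why the two compounds read alike.

The compounds shown leave open whether a different group at this position, such as a methoxy group, an amine or a longer chain in place of the methyl, would move the number beyond the scatter. Compound 1 differs from compound 2 and compound 3 in more than one place, so the contribution of each of its differences, including its ethyl ester, cannot be separated.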